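A few compounds are considered here, and "the series" means these few. Any claim that something is new, unique, unknown or untested is made for them only; others in the source may bear on it.

Working notes on the series, read in a functional assay on A549 cells (Homo sapiens) for inhibition, read by MTT assay, with a stated time of 48 h; on this read-out higher numbers stand for weaker inhibition and lower numbers for stronger inhibition:

- compound 1 `Cn1c(/C=C2\SC(=O)N(CC(=O)N3CCOCC3)C2=O)nc2ccccc21`: 38500 nM
- compound 2 `CCn1c(/C=C2\SC(=O)N(CC(=O)N3CCCC3)C2=O)nc2ccccc21`: 31200 nM
- compound 3 `CCn1c(/C=C2\SC(=O)N(CC(=O)N3CC(C)OC(C)C3)C2=O)nc2ccccc21`: > 50000 nM
- compound 4 `CCn1c(/C=C2\SC(=O)N(CC(=O)N3CCOCC3)C2=O)nc2ccccc21`: not yet measured

Compound 3 stands at > 50000 nM, which is a limit of the assay and not a number.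

The next step leads to compound 4. The change is morpholin-4-yl in place of 2,6-dimethylmorpholin-4-yl on a carbonyl carbon.

Among the measured compounds shown here, one measured step bears on it directly, the other change at the same place: an at least 1.6-fold higher number from compound 2 to compound 3 (0.20 log units; that floor lies within the scatter). That step has only a floor, so it sets no firm size. Compound 2, at 31200 nM, shows that a measurable number is reached without the 2,6-dimethylmorpholin-4-yl group. Compound 1, at 38500 nM, also carries morpholin-4-yl on a carbonyl carbon and gives the closest guide to the level of compound 4. The values of compound 1 and compound 2 lie within the scatter of each other.

In this assay a small move towards a lower number is therefore expected, possibly no larger than the scatter. The expected step is an at least 1.3-fold lower number from compound 3 to compound 4 (0.13 log units; that floor lies within the scatter).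

For compound 4 the estimate is 37000 nM, with an expected range from 22000 nM to 60000 nM.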

Compound 4, half-maximal inhibitory concentration: > 50000 nM
Compound 4 ended at the assay's limit (the forecaster's own chance of this, stated with the estimate: 20%); at least 1.3-fold (0.13 log units) between middle value and limit.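

In this assay compound 4 gives > 50000 nM, which is a limit of the assay and not a number. Morpholin-4-yl in place of 2,6-dimethylmorpholin-4-yl on a carbonyl carbon therefore yields no measurable number here, and the step between the two compounds cannot be read, as both sit at the same limit: the limit of > 50000 nM in this assay, at which 2 of the 4 values shown sit.

The two readable steps are an at least 1.6-fold higher number from compound 2 to compound 4 (0.20 log units; that floor lies within the scatter) for morpholin-4-yl in place of pyrrolidin-1-yl, and an at least 1.2-fold higher number from compound 1 to compound 4 (0.11 log units; that floor lies within the scatter) for methyl in place of hydrogen on a saturated chain carbon bound to an aromatic nitrogen, so neither change is shown to reach a size beyond the scatter.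

Open, from the compounds shown here alone, is whether a piperidin-1-yl group, an amine or a carboxylic acid in place of morpholin-4-yl on a carbonyl carbon would give a number clear of the limit. Also open is whether a longer chain on the aromatic nitrogen would move the read-out in either direction, since the compounds shown give no firm size for any change at that place.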